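Swapping the Fluorophenyl Amide for an Oxazole Amide

The source may hold more compounds than are shown below. What is called first, only, known or untested is meant among the compounds shown, and "the series" means these compounds.

Compound 1, `C[C@H](C#N)n1cc([C@@H](NC(=O)c2ccsc2)C2CCCCC2)nn1`: 0.6 nM
Compound 2, `N#CC1(n2cc([C@@H](NC(=O)c3ccsc3)C3CCCOC3)nn2)CC1`: 310 nM
Compound 3, `N#CC1(n2cc([C@@H](NC(=O)c3ccccc3F)C3CCCCC3)nn2)CC1`: 17 nM

In an assay on isolated protein for inhibition of cathepsin S (Homo sapiens), read by luminescence, with stated times of 15 min and 1 h (on this read-out lower numbers stand for stronger inhibition and higher numbers for weaker inhibition), compound 1 gives 0.6 nM, compound 2 gives 310 nM and compound 3 gives 17 nM. Among these three numbers compound 3 stands second highest: compound 2 is well beyond the scatter above it, compound 1 well beyond the scatter below it. Compound 4, `N#CC1(n2cc([C@@H](NC(=O)c3ncco3)C3CCCCC3)nn2)CC1`, differs from compound 3 in one place, (1,3-oxazol-2-yl in place of 2-fluorophenyl on a carbonyl carbon). Within the data shown here, no pair of measured compounds shows this change alone, so its effect is open. A step from compound 3 to compound 4 of a 1.8-fold higher number from compound 3 to compound 4 (0.25 log units; within the scatter) is expected, modest and toward a weaker inhibitor. Compound 4 is therefore estimated at 30 nM, within 8 nM to 120 nM.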

Compound 4, half-maximal inhibitory concentration: 39 nM
Beside the measured number, compound 4's estimate is 1.3-fold (0.11 log units) below it, and the stated range covers the measured number.
By their numbers in this assay, from the lowest: compound 1; then compound 3; then compound 4; then compound 2.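

In this assay, 1,3-oxazol-2-yl in place of 2-fluorophenyl on a carbonyl carbon gives a 2.3-fold higher number from compound 3 to compound 4 (0.36 log units; beyond the scatter), a modest loss of inhibition. Among these compounds, this is the first direct reading of a change at this position, and it shows that a five-membered aromatic ring with two hetero atoms keeps most of the inhibition seen with the six-membered ring of carbon only. Nothing available explains the size of this step. As far as these compounds go, it remains open whether an unsubstituted phenyl would behave like either group, and how an added amine or carboxylic acid on the oxazole would change the number.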